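The source may hold more compounds than are shown below. What is called first, only, known or untested is meant among the compounds shown, and "the series" means these compounds.

Measured in an ADME assay on HaCaT cells (Homo sapiens) for inhibition; on this read-out lower numbers stand for stronger inhibition and higher numbers for weaker inhibition:
Compound 1 `COc1cc(-c2cc(C(=O)O)c3ccccc3n2)ccc1OCC(=O)Nc1cccc(C)c1`: 225000 nM
Compound 2 `COc1cc(-c2cc(C(=O)O)c3ccccc3n2)ccc1OCC(=O)Nc1cccc(F)c1`: 148000 nM
Compound 3 `COc1cc(-c2cc(C(=O)O)c3ccccc3n2)ccc1OCC(=O)Nc1ccc(F)cc1`: 286000 nM

Compound 3 shows no clear separation from the other two. The steps are a 1.3-fold higher number from compound 1 to compound 3 (0.10 log units; within the scatter) and a 1.9-fold higher number from compound 2 to compound 3 (0.29 log units; within the scatter). The remaining step, a 1.5-fold lower number from compound 1 to compound 2 (0.18 log units; within the scatter), also lies within the scatter. Together these three steps show that swapping among these substituted phenyl groups on the amide nitrogen has not yet moved the number measurably.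

Compound 4 `COc1cc(-c2cc(C(=O)O)c3ccccc3n2)ccc1OCC(=O)NCc1ccccc1` makes a different kind of change, with benzyl in place of 4-fluorophenyl on an amide-type nitrogen. Among the compounds with values here, no measured compound carries a benzyl group, so the three steps offer only indirect guidance and the range must stay wide. They give no reason to expect a real shift in this assay, so none beyond the scatter is expected. The estimate is a 1.4-fold lower number from compound 3 to compound 4 (0.16 log units; within the scatter). Compound 4 is expected at about 200000 nM, with an estimated range of 80000 nM to 450000 nM.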

Compound 4, half-maximal inhibitory concentration: > 300000 nM
Compound 4 gave a limit, no number (the forecaster's own chance of this, stated with the estimate: 10%); at least 1.5-fold (0.17 log units) between middle value and limit.
By their numbers in this assay, from the lowest: compounds 2, 1 and 3 (each within the scatter of the next). At a limit, above all of these: compound 4.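

In this assay compound 4 gives a limit and not a number, > 300000 nM. The steps to it are therefore floors only: an at least 1.0-fold higher number from compound 3 to compound 4 (0.02 log units; that floor lies within the scatter), an at least 2.0-fold higher number from compound 2 to compound 4 (0.30 log units; that floor lies within the scatter) and an at least 1.3-fold higher number from compound 1 to compound 4 (0.12 log units; that floor lies within the scatter). Benzyl is the only group shown on the amide-type nitrogen that is not a substituted phenyl, and this change cannot yet be ranked against the other three compounds: the limit of > 300000 nM in this assay, at which 1 of the 4 values shown sits.

Going by these compounds, how far compound 4 really lies from the others stays open, as does the reading of a longer chain such as 2-phenylethyl or of a group carrying an amine on this nitrogen. Also open, on these data alone, is what an ester in place of the carboxylic acid on the shared core would do in this assay.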